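A few compounds are considered here, and "the series" means these few. Any claim that something is new, unique, unknown or untested is made for them only; others in the source may bear on it.

In an ADME assay on cells (Splenocyte, Mus musculus, strain BALB/c) for cytotoxicity, read by MTT assay, tested at 10 ug/mL (on this read-out lower numbers stand for a weaker effect and higher numbers for a stronger effect at the one concentration tested), the three measured compounds gave these numbers:

compound 1, `CCCCCCCCCCCCCCC(NC(=O)OC(C)(C)C)C(=O)O`: 5.1%
compound 2, `CCCCCCCCCCCCCCC(COCc1ccccc1)N(CC)CC`: 15.6%
compound 3, `CCCCCCCCCCCCCCC(CO)N(CC)CC`: 12.8%

Compound 3 holds the second highest of the three numbers; its gaps to compound 2 and to compound 1 both lie within the scatter. Compound 4, `CCCCCCCCCCCCCCC(C(=O)O)N(CC)CC`, is not yet measured; it differs from compound 3 by carboxy in place of hydroxymethyl on a saturated chain carbon bound to an amine nitrogen and a saturated chain carbon. For the measured compounds named here, the one measured step, a number 2.8 percentage points lower from compound 2 to compound 3 (within the scatter), concerns an oxygen on a saturated carbon, not this place, so nothing bears closely on the change. Compound 1, which also carries a carboxy, differs in several places and gives no clean comparison. A step within the scatter is expected, a number 0.8 percentage points lower from compound 3 to compound 4 (within the scatter). Compound 4 is estimated at 12%, between 3% and 22%.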

Compound 4, a percentage reported as activity, at one concentration (the size of the read-out at that concentration, not a potency): 12.1%
Compound 4: middle estimate off by 0.1 percentage points, on the low side, within the range that was stated.
By their numbers in this assay, from the lowest: compounds 1, 4, 3 and 2 (each within the scatter of the next, the first and the last beyond it).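

In this assay, carboxy in place of hydroxymethyl on this carbon gives a number 0.7 percentage points lower from compound 3 to compound 4 (within the scatter) and carboxy in place of (benzyloxy)methyl gives a number 3.5 percentage points lower from compound 2 to compound 4 (within the scatter) at the same place, so these three groups cannot be told apart here. With the carboxy kept, diethylamino in place of (tert-butoxycarbonyl)amino gives a number 7 percentage points higher from compound 1 to compound 4 (within the scatter) as well. No measurement at hand offers an explanation for these results.

As far as these compounds go, whether a primary amine or a methyl ester on this carbon would give a number beyond the scatter stays open, as does the effect of a shorter chain.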